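Adding a pyridinyloxy group to the pyridylmethyl analogue

The source may hold more compounds than are shown below. What is called first, only, known or untested is meant among the compounds shown, and "the series" means these compounds.

The three measured compounds share one core. In a functional assay for antagonist activity at P2X purinoceptor 7 (Rattus norvegicus), read by FLIPR and calcium flux (on this read-out lower numbers stand for stronger inhibition and higher numbers for weaker inhibition), compound 1 `Clc1cccc(-n2ncnc2Nc2ccccc2)c1Cl` gives 3890 nM, compound 2 `Clc1cccc(-n2ncnc2NCc2ccccc2)c1Cl` gives 209 nM, and compound 3 `Clc1cccc(-n2ncnc2NCc2cccnc2)c1Cl` gives 1320 nM. Compound 3 therefore stands second highest of the three: the step of a 2.9-fold lower number from compound 1 to compound 3 (0.47 log units; beyond the scatter) brought it below compound 1, while the step of a 6.3-fold higher number from compound 2 to compound 3 (0.80 log units; beyond the scatter) left it well above compound 2. The large step of a 19-fold lower number from compound 1 to compound 2 (1.27 log units; beyond the scatter) shows how much the benzyl linker matters.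

Compound 4 `Clc1cccc(-n2ncnc2NCc2cccnc2Oc2cccnc2)c1Cl` differs from compound 3 by (pyridin-3-yl)oxy in place of hydrogen on an aromatic carbon. For the measured compounds named here, none of the measured steps changes a substituent on this ring; they alter the linker or swap phenyl for pyridinyl, so no direct precedent exists. With the pyridinyl ring kept and only a group appended, the step of a 1.5-fold lower number from compound 3 to compound 4 (0.17 log units; within the scatter) is expected to stay close to no change, with a modest lowering considered slightly more likely than a rise. Compound 4 is therefore estimated at 900 nM in this assay, with a range from 200 nM to 4000 nM.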

Compound 4, half-maximal inhibitory concentration: 129 nM
Estimate against measurement, compound 4: 7.0-fold (0.84 log units) above; measured number outside the range, below it.
By their numbers in this assay, from the lowest: compounds 4 and 2 (each within the scatter of the next); then compound 3; then compound 1.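

In this assay there is a 10-fold lower number from compound 3 to compound 4 (1.01 log units; beyond the scatter), so the aromatic carbon next to the ring nitrogen accepts a group of 7 heavy atoms, and here that addition goes with much stronger inhibition. The earlier steps shown here changed only the linker or swapped phenyl for pyridinyl, whereas this one shows that adding a group to the ring itself can also produce a large step, as the linker change did with a 19-fold lower number from compound 1 to compound 2 (1.27 log units; beyond the scatter). No measurement shown here accounts for this gain.

On these data alone, whether the gain needs the whole group stays open: a methoxy or a phenoxy group on the same carbon would separate the oxygen link from the added ring and its nitrogen. Also open, as far as these compounds go, is whether (pyridin-3-yl)oxy would lower the number on the phenyl ring of compound 2.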